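Ester to nitrile on the side chain of compound 1

The source may report more compounds than this note shows. Statements on the series, on what has been measured and on what is new or still open speak of the compounds shown alone.

Measured so far:
Compound 1, `COC(=O)CCCc1onc(NS(=O)(=O)c2ccc(C(C)(C)C)cc2)c1Sc1cccc(OC)c1`: in an assay on A7R5 cells for displacement of a labelled ligand from Endothelin-1 receptor (Rattus norvegicus) (a higher number here means a weaker inhibitor, a lower number a stronger inhibitor), compound 1 gives 400 nM.
Compound 2, `Cc1onc(NS(=O)(=O)c2ccc(N)cc2)c1I`: in this assay compound 2 gives 11000 nM.

Of the two compounds measured, compound 1 has the lower number, and its gap to compound 2 lies beyond the usual scatter, so compound 1 is the stronger inhibitor of the pair. Compound 3, `COc1cccc(Sc2c(NS(=O)(=O)c3ccc(C(C)(C)C)cc3)noc2CCCC#N)c1`, has not yet been measured. It differs from compound 1 in one place: cyano in place of methoxycarbonyl on a saturated chain carbon, three bonds along the chain from an aromatic carbon. Among the measured compounds shown here, no pair of measured compounds shows what this kind of exchange does here, so the only anchor is compound 1 itself at 400 nM. The step of no change at the digits printed from compound 1 to compound 3 (within the scatter) is expected to stay within the scatter, with no clear direction. Compound 3 is therefore estimated at 400 nM in this assay, with a range from 150 nM to 1100 nM.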

Compound 3, half-maximal inhibitory concentration: 1300 nM
Compound 3: the middle estimate sits 3.3-fold (0.51 log units) below what was measured, outside the stated range (above it).
By their numbers in this assay, from the lowest: compound 1; then compound 3; then compound 2.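

Until now, nothing showed whether the group at the end of this side chain matters in this assay and here the exchange of methoxycarbonyl for cyano gives a 3.3-fold higher number from compound 1 to compound 3 (0.51 log units; beyond the scatter) and so a weaker inhibitor. The two groups are therefore not interchangeable on a saturated chain carbon, three bonds along the chain from an aromatic carbon, although the step is modest and methoxycarbonyl is the better of the two compared. Nothing available explains why the number rises with this change.

A single pair cannot show whether other end groups, such as a carboxylic acid, a primary amide or an amine, would match methoxycarbonyl or fall further behind. Also open, on these data alone, is whether a longer chain would change the gap between the ester and the nitrile.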